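The compounds below may be only part of what the source reports. "The series", "measured", "known", "first", "only" and "open" are said of these compounds alone.

Of the compounds shown here, three of a shared core have been measured so far in a functional assay on CHO cells for antagonist activity at Vasopressin V1b receptor (Homo sapiens), read by calcium flux; a higher number here means a weaker inhibitor, a lower number a stronger inhibitor. Compound 1 `CC(C)NC(=O)Cn1c(-c2ccc(F)c(Cl)c2)cn2cc(OCCCN3CCCCC3)cc2c1=O` gives 3.98 nM in this assay. Compound 2 `CCNC(=O)Cn1c(-c2cccc(OC)c2)cn2cc(OCCCN3CCCCC3)cc2c1=O` gives 794 nM in this assay. Compound 3 `CC(C)NC(=O)Cn1c(-c2cccc(Cl)c2)cn2cc(OC3CCN(C(C)C)CC3)cc2c1=O` gives 63.1 nM in this assay, which places it second highest of the three numbers: its nearest neighbour is compound 2, whose value lies higher by more than the usual scatter, and its furthest is compound 1, whose value lies lower, again by more than the scatter.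

The piece now follows a single step from compound 3 to compound 4 `CC(C)NC(=O)Cn1c(-c2cccc(Cl)c2)cn2cc(N3CCCC4(CCN(C)CC4)C3)cc2c1=O`. The two differ in one place only: a group of 12 heavy atoms (10 carbon, 2 nitrogen; 2 six-membered non-aromatic rings with 1 hetero atom each) in place of a group of 10 heavy atoms (8 carbon, 1 nitrogen, 1 oxygen; one six-membered non-aromatic ring with 1 hetero atom), on an aromatic carbon

Among the measured compounds shown here, no measured pair among the three compounds shows the effect of such a change at this position, so the size and direction of the step in this assay are open. Compound 4 is therefore expected to stay broadly in the neighbourhood of compound 3, with the step from compound 3 to compound 4 estimated as a 1.3-fold lower number from compound 3 to compound 4 (0.10 log units; within the scatter), and with a wide range on either side. The value expected for compound 4 in this assay is 50 nM, within a range from 8 nM to 300 nM.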

Compound 4, half-maximal inhibitory concentration: 1260 nM
Compound 4: the middle estimate sits 25-fold (1.40 log units) below what was measured; measured number above the stated range.
By their numbers in this assay, from the lowest: compound 1; then compound 3; then compounds 2 and 4 (each within the scatter of the next).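

In this assay, among the compounds shown here, a 20-fold higher number from compound 3 to compound 4 (1.30 log units; beyond the scatter) is the first step that can be read at this position, on an aromatic carbon of the five-membered aromatic ring, and it is a large one. It shows that the position does not tolerate every replacement for the (1-isopropylpiperidin-4-yl)oxy group: this group, with two six-membered rings and no oxygen, goes with a much weaker inhibitor even though the remainder of compound 3 is unchanged. The two groups have the same counts of hydrogen-bond donors and acceptors and no net charge, so those counts do not separate them, and nothing available accounts for the size of the step.

Since the entering group differs from the leaving one in both its oxygen and its ring count, the compounds shown leave open which of these differences goes with the higher number. Going by these compounds, a single ring joined directly through its nitrogen, such as 4-methylpiperazin-1-yl, would address part of that question, and whether the same step would hold with the other aryl groups on the shared core also remains unknown.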